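The source may report more compounds than this note shows. Statements on the series, on what has been measured and on what is new or still open speak of the compounds shown alone.

Measured compounds in a functional assay on SK-BR-3 cells (Homo sapiens) for antiproliferative activity, read by MTT assay, with a stated time of 72 h; on this read-out lower numbers stand for stronger inhibition and higher numbers for weaker inhibition:
compound 1 `CCN1CCN(c2cc(C)c3cc(NC(=O)c4ccccc4)ccc3n2)CC1` — compound 1 gives 18400 nM
compound 2 `Cc1cc(NCCN(C)C)nc2ccc(NC(=O)c3ccc(Cl)c(Cl)c3)cc12` — compound 2 gives 6670 nM
compound 3 `CCN1CCN(c2cc(C)c3cc(NC(=O)c4cccc(Cl)c4)ccc3n2)CC1` — compound 3 gives 17800 nM

Compound 2 holds the lowest number of the three in this assay; its nearest neighbour is compound 3, and compound 1 stands furthest off, both gaps beyond the scatter. Within the data shown here, the only one-place step in the set is a 1.0-fold lower number from compound 1 to compound 3 (0.01 log units; within the scatter), and it concerns the aromatic chloro, not the amine chain.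

Compound 4 `CCN(CC)CCNc1cc(C)c2cc(NC(=O)c3ccc(Cl)c(Cl)c3)ccc2n1` is not yet measured. It differs from compound 2 in one place: diethylamino in place of dimethylamino on a saturated chain carbon, two bonds along the chain from a nitrogen on an aromatic ring. Among the measured compounds shown here, no measured pair varies the terminal amine on the chain, so nothing in the data speaks to this step directly. For the measured compounds named here, compound 2 and compound 4 share everything else, and with no step to lean on the working expectation in this assay is a change that stays within the scatter, in no fixed direction. For compound 4 the estimate is 6700 nM, within 3000 nM to 15000 nM, which is expected to mean a 1.0-fold higher number from compound 2 to compound 4 (0.00 log units; within the scatter).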

Compound 4, half-maximal inhibitory concentration in the SK-BR-3 assay: 3710 nM
For compound 4 the middle estimate is 1.8-fold (0.26 log units) above the measured one; the range from low to high includes it.
By their numbers in the SK-BR-3 assay, from the lowest: compounds 4 and 2 (each within the scatter of the next); then compounds 3 and 1 (each within the scatter of the next).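

Among these compounds, compound 2 and compound 4 are the one measured pair that varies the terminal amine on the chain, and in a physicochemical assay for lipophilicity, at pH 7.4 (on this read-out lower numbers stand for lower lipophilicity and higher numbers for higher lipophilicity), compound 2 gives 1.47 and compound 4 gives 1.66. In the SK-BR-3 assay the step reads a 1.8-fold lower number from compound 2 to compound 4 (0.25 log units; within the scatter) and shows that diethylamino in place of dimethylamino at this place on the chain stays within the scatter, while in the physicochemical assay the same change reads a number 0.19 log units higher from compound 2 to compound 4 (within the scatter) and also stays within the scatter. No measurement at hand explains either result.

On these data alone, it remains open whether a piperidine or morpholine at the chain end, or a longer chain carrying the same diethylamino group, would take the number beyond the scatter. This change has been read only with the amide part shared by compound 2 and compound 4, so its size with other amide parts is also unknown.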